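A few compounds are considered here, and "the series" means these few. Any claim that something is new, unique, unknown or untested is made for them only; others in the source may bear on it.

Within the data shown here, in a functional assay on MCF7 cells (Homo sapiens) for antiproliferative activity, read by MTT assay, with a stated time of 48 h (a higher number here means a weaker inhibitor, a lower number a stronger inhibitor), compound 2 `COc1ccc(C(=O)Nc2cc3cnc(NCCN(C)C)cc3n(C)c2=O)cc1` gives 37300 nM, the higher of the two numbers measured so far. The other comes from compound 1 `CN(C)CCNc1cc2c(cn1)cc(NC(=O)c1ccc(Cl)cc1)c(=O)n2C`, at 3090 nM. Compound 3 `CN(C)CCNc1cc2c(cn1)cc(NC(=O)c1ccccc1)c(=O)n2C` is still unmeasured and has hydrogen in place of methoxy on an aromatic carbon. Among the measured compounds shown here, one measured step bears on this change, methoxy in place of chloro on an aromatic carbon, and it is large: a 12-fold higher number from compound 1 to compound 2 (1.08 log units; beyond the scatter). Hydrogen is neither of those groups, so a moderate move towards a lower number is expected, an estimated 3.1-fold lower number from compound 2 to compound 3 (0.49 log units; beyond the scatter). The estimate for compound 3 is 12000 nM, with an expected range from 3000 nM to 40000 nM.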

Compound 3, half-maximal inhibitory concentration: 35100 nM
Compound 3: the middle estimate sits 2.9-fold (0.47 log units) below what was measured, within the range that was stated.
By their numbers in this assay, from the lowest: compound 1; then compounds 3 and 2 (each within the scatter of the next).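

In this assay, methoxy and hydrogen at this place, para to a large group, read alike, with a 1.1-fold lower number from compound 2 to compound 3 (0.03 log units; within the scatter). Chloro is the group that stands apart, with an 11-fold higher number from compound 1 to compound 3 (1.06 log units; beyond the scatter), so the lower number of compound 1 goes with having chloro there rather than with lacking methoxy. Nothing available explains why chloro separates from the other two groups. Still open, going by these compounds, is whether bromo, fluoro or an amine at this place would behave like chloro or like hydrogen.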